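The source may hold more compounds than are shown below. What is called first, only, known or untested is meant among the compounds shown, and "the series" means these compounds.

In a functional assay on MGC-803 cells (Homo sapiens) for antiproliferative activity, read by MTT assay, with a stated time of 48 h (on this read-out higher numbers stand for an effect only at larger amounts of compound and lower numbers for an effect already at smaller amounts), the series reads as follows:
Compound 1 `CC1=NN(S(=O)(=O)c2ccccc2C)C(c2cc(Br)ccc2O)C1` gives > 60000 nM (a limit, not a number)
Compound 2 `CC1=NN(S(=O)(=O)c2ccc([N+](=O)[O-])cc2)C(c2cc(Br)ccc2O)C1` gives 22200 nM
Compound 3 `CC1=NN(S(=O)(=O)c2ccc(F)cc2)C(c2cc(Br)ccc2O)C1` gives 15500 nM

Compound 3 stands level with compound 2, the two values lying within the scatter of each other (a 1.4-fold lower number from compound 2 to compound 3 (0.16 log units; within the scatter)). Compound 1 offers only a limit (the limit of > 60000 nM in this assay, at which 1 of the 3 values shown sits). Even so, the step to compound 3 lies beyond the scatter (an at least 3.8-fold lower number from compound 1 to compound 3 (0.58 log units; beyond the scatter)).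

The next change leads from compound 3 to compound 4 `CC1=NN(S(=O)(=O)c2ccc(Cl)cc2)C(c2cc(Br)ccc2O)C1`, with chloro in place of fluoro on an aromatic carbon, para to a large group (chloro in place of fluoro on an aromatic carbon). Among the compounds with values here, two measured steps bear on it. The closer one, fluoro in place of nitro on an aromatic carbon, stayed within the scatter (a 1.4-fold lower number from compound 2 to compound 3 (0.16 log units; within the scatter)). The other, 4-fluorophenyl in place of 2-methylphenyl on a sulfonyl sulfur, is a different kind of change and starts from a limit. No step beyond the scatter is therefore expected in this assay, and no direction is favoured. The estimated change is small (a 1.0-fold lower number from compound 3 to compound 4 (0.01 log units; within the scatter)). The expected value for compound 4 is 15000 nM (estimated range 7000 nM to 33000 nM).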

Compound 4, half-maximal effective concentration: > 60000 nM
Compound 4 ended at the assay's limit; the forecaster's own chance of this, stated with the estimate: 8%; middle value at least 4.0-fold (0.60 log units) away from the limit.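

In this assay, the two halogens are not interchangeable on this aromatic carbon, para to a large group: chloro in place of fluoro gives a step beyond the scatter (an at least 3.8-fold higher number from compound 3 to compound 4 (0.58 log units; beyond the scatter)). Chloro in place of nitro also goes beyond the scatter (an at least 2.7-fold higher number from compound 2 to compound 4 (0.43 log units; beyond the scatter)), whereas fluoro in place of nitro stayed within it (a 1.4-fold lower number from compound 2 to compound 3 (0.16 log units; within the scatter)), so this position now separates chloro from the other two groups. Compound 4 gives a limit rather than a number, and the step between compound 1 and compound 4 cannot be read: the limit of > 60000 nM in this assay, at which 2 of the 4 values shown sit.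

As far as these compounds go, the full size of the steps to chloro remains open. Also open, from the compounds shown here alone, is whether an amine, a carboxylic acid or a methoxy group at this position would read like fluoro and nitro or like chloro.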